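A few compounds are considered here, and "the series" means these few. Any claim that something is new, unique, unknown or untested is made for them only; others in the source may bear on it.

Compound 1 `CO/N=C(\C)c1ccc(Sc2cc(F)cc(C3CCOCC3)c2)cc1`: 110 nM
Compound 2 `CN(C)/C(=N\O)c1ccc(Sc2cc(F)cc(C3CCOCC3)c2)cc1`: 280 nM
Compound 3 `CC(C)/C(=N\O)c1ccc(Sc2cc(F)cc(C3CCOCC3)c2)cc1`: 300 nM

These three compounds share one core and differ only in the group attached to a single aromatic carbon. All were tested in a functional assay (blood) for inhibition, with Homo sapiens as the target; on this read-out lower numbers stand for stronger inhibition and higher numbers for weaker inhibition. Among the three numbers compound 3 stands highest, which here means the weakest inhibition measured. Its nearest neighbour is compound 2, and that gap, a 1.1-fold higher number from compound 2 to compound 3 (0.03 log units; within the scatter), lies within the scatter, so the two cannot be told apart. The gap to compound 1 is larger: a 2.7-fold higher number from compound 1 to compound 3 (0.44 log units; beyond the scatter).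

Compound 4 `CC(=O)O/N=C(\C)c1ccc(Sc2cc(F)cc(C3CCOCC3)c2)cc1` has not yet been measured. Against compound 3 the change is a group of 7 heavy atoms (4 carbon, 1 nitrogen, 2 oxygen; no ring) in place of a group of 6 heavy atoms (4 carbon, 1 nitrogen, 1 oxygen; no ring), on an aromatic carbon. For the measured compounds named here, the steps that bear on it are the two leading away from compound 1: a 2.7-fold higher number from compound 1 to compound 3 (0.44 log units; beyond the scatter) and a 2.5-fold higher number from compound 1 to compound 2 (0.41 log units; beyond the scatter), both modest moves toward weaker inhibition. Compound 4 resembles compound 1 more closely than compound 3 does, so the change is expected to recover part of that ground, a step of a 2.0-fold lower number from compound 3 to compound 4 (0.30 log units; within the scatter) toward stronger inhibition. Compound 4 is therefore estimated at 150 nM in this assay, with a range from 50 nM to 450 nM.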

Compound 4, half-maximal inhibitory concentration: 50 nM
For compound 4 the middle estimate is 3.0-fold (0.48 log units) above the measured one, and the stated range covers the measured number.
By their numbers in this assay, from the lowest: compound 4; then compound 1; then compounds 2 and 3 (each within the scatter of the next).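

In this assay, for the compounds shown here, acetyl in place of methyl on the oxygen gives a step toward stronger inhibition (a 2.2-fold lower number from compound 1 to compound 4 (0.34 log units; beyond the scatter)), the first change at this position to move in that direction from the methyl compound, since both earlier steps away from it led toward weaker inhibition. The gaps to the two remaining compounds are wider (a 6.0-fold lower number from compound 3 to compound 4 (0.78 log units; beyond the scatter); a 5.6-fold lower number from compound 2 to compound 4 (0.75 log units; beyond the scatter)), and with all three steps beyond the scatter, compound 4 is the strongest inhibitor of the four. Going from compound 3 to compound 4 alters several things at once, as the hydrogen-bond donors go from 1 to 0, the hydrogen-bond acceptors go from 2 to 3, and a carbonyl enters, so these numbers cannot show which of these matters.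

Nothing measured here accounts for the gain seen with the acetyl group. Also open, going by these compounds, is whether a longer chain on the same oxygen, such as propanoyl, or a benzoyl group would lower the number further or raise it again.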